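The compounds below may be only part of what the source reports. "The series", "measured", "known", "first", "only" and "open" are said of these compounds alone.

Measured in a functional assay on MCF7 cells (Homo sapiens) for antiproliferative activity, read by sulforhodamine B assay, with a stated time of 48 h; a lower number here means a stronger inhibitor, a higher number a weaker inhibitor:
- Compound 1 `CN1CCN(c2ccc(S(=O)(=O)Oc3cc(Cl)c(Cl)cc3Cl)cc2)C1=O` gives 630 nM
- Compound 2 `CCN1CCN(c2ccc(S(=O)(=O)Oc3cccc(F)c3)cc2)C1=O` gives > 100000 nM, a limit of the assay and not a number
- Compound 3 `CCCN1CCN(c2ccc(S(=O)(=O)Oc3cc(Cl)c(Cl)cc3Cl)cc2)C1=O` gives 13000 nM

Only compound 1 and compound 3 have true numbers, and compound 3 has the higher one, making it the weaker inhibitor of the two. The gap is a 21-fold higher number from compound 1 to compound 3 (1.31 log units; beyond the scatter), a large step, but it comes from a change in the chain and not in the group on oxygen.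

Compound 4 `CCCN1CCN(c2ccc(S(=O)(=O)Oc3ccc(C)cc3)cc2)C1=O` keeps the chain of compound 3 and carries 4-methylphenyl in place of 2,4,5-trichlorophenyl on an oxygen. Within the data shown here, no measured step changes this group alone, so the size of the step has to be judged loosely.

The nearest hint is compound 2, which lacks the 2,4,5-trichlorophenyl group and also differs in the chain, and which reports only (the limit of > 100000 nM in this assay, at which 1 of the 3 values shown sits). This one limit suggests a move toward weaker inhibition in this assay, and a limit is possible here too.

The expected change is a 3.1-fold higher number from compound 3 to compound 4 (0.49 log units; beyond the scatter), toward a higher number. For compound 4 the estimated value is 40000 nM, with an expected range from 10000 nM to 100000 nM.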

Compound 4, half-maximal inhibitory concentration: 64000 nM
Estimate against measurement, compound 4: 1.6-fold (0.20 log units) below; measured number inside the range.
By their numbers in this assay, from the lowest: compound 1; then compound 3; then compound 4. At a limit, above all of these: compound 2.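

With the chain of compound 3 held fixed, placing 4-methylphenyl instead of 2,4,5-trichlorophenyl on the oxygen gives, in this assay, a 4.9-fold higher number from compound 3 to compound 4 (0.69 log units; beyond the scatter). Among these compounds, this is the first direct reading of this position: the group on the oxygen bound to the sulfonyl sulfur does affect the result, but the step is a modest one, and compound 4 still gives a true number even without the 2,4,5-trichlorophenyl group. Compound 2 remains the only compound reported at a limit, which is not a number: the limit of > 100000 nM in this assay, at which 1 of the 4 values shown sits.

Among the compounds shown here, the single step removes all the chlorine and adds a methyl at once, so it cannot show which of the two changes accounts for the difference, and an unsubstituted phenyl group on the same oxygen would help to separate them. As far as these compounds go, it also remains open whether 4-methylphenyl would produce a similar step on the shorter chain of compound 1, since the size of this step is known only on the chain of compound 3.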